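The source may report more compounds than this note shows. Statements on the series, on what has been measured and on what is new or still open speak of the compounds shown alone.

Of the compounds shown here, three that share one core have been measured in a functional assay on isolated protein for inhibition of Glucose-dependent insulinotropic receptor (Homo sapiens), read by HTRF and cAMP accumulation; on this read-out higher numbers stand for an effect only at larger amounts of compound and lower numbers for an effect already at smaller amounts. Compound 1 `Cc1nc(S(C)(=O)=O)ccc1Oc1ncnc(OC2CCN(C(=O)OC(C)(C)C(F)(F)F)CC2)c1F` gives 6.53 nM in this assay. Compound 2 `Cc1nc(S(C)(=O)=O)ccc1Oc1ncnc(OC2CCN(C(=O)SC(C)C)CC2)c1F` gives 6.8 nM in this assay. Compound 3 `Cc1nc(S(C)(=O)=O)ccc1Oc1ncnc(OC2CCN(C(=O)SC3CC3)CC2)c1F` gives 24.9 nM in this assay, the highest of the three numbers; its nearest neighbour is compound 2 and its furthest is compound 1, and both of those gaps lie beyond the scatter. The steps among them are a 1.0-fold higher number from compound 1 to compound 2 (0.02 log units; within the scatter), a 3.8-fold higher number from compound 1 to compound 3 (0.58 log units; beyond the scatter) and a 3.7-fold higher number from compound 2 to compound 3 (0.56 log units; beyond the scatter).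

Compound 4 `Cc1nc(S(C)(=O)=O)ccc1Oc1ncnc(OC2CCN(C(=O)C3(F)CCC3)CC2)c1F` differs from compound 3 in a group of 5 heavy atoms (4 carbon, 1 fluorine; one four-membered non-aromatic ring of carbon only) in place of a group of 4 heavy atoms (3 carbon, 1 sulfur; one three-membered non-aromatic ring of carbon only), on a carbonyl carbon. For the measured compounds named here, no measured step makes this exact exchange. All three measured steps, however, vary the group on the same carbonyl carbon, and the largest of them stayed modest, so the group attached there appears to shift this assay by no more than a modest amount across the compounds seen. Since compound 3 already stands at the high end of the three numbers, a modest move back toward the numbers of compounds 1 and 2 is the most plausible outcome, with a result within the scatter of compound 3 also possible. The estimate for compound 4 is 12 nM, with a range from 3.5 nM to 40 nM, meaning an expected step of a 2.1-fold lower number from compound 3 to compound 4 (0.32 log units; beyond the scatter).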

Compound 4, half-maximal effective concentration: 24.7 nM
Compound 4: middle estimate off by 2.1-fold (0.31 log units), on the low side; low and high end bracket the measured number.
By their numbers in this assay, from the lowest: compounds 1 and 2 (each within the scatter of the next); then compounds 4 and 3 (each within the scatter of the next).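

In this assay, the four-membered carbon ring carrying fluorine on the carbonyl carbon and the three-membered carbon ring group joined through sulfur cannot be told apart, at a 1.0-fold lower number from compound 3 to compound 4 (0.00 log units; within the scatter), so at this position a ring group without sulfur can read the same as one with it. Both open-chain groups differ from the new ring group, at a 3.6-fold higher number from compound 2 to compound 4 (0.56 log units; beyond the scatter) and a 3.8-fold higher number from compound 1 to compound 4 (0.58 log units; beyond the scatter), both modest and beyond the scatter, so among these four compounds the two ring-bearing groups sit together at higher numbers and the two open-chain groups together at lower numbers, with no compound going against this split, although the step to the sulfur-linked open chain in compound 2 and the step to the oxygen-linked open chain in compound 1 also show that the linking atom alone does not set the number. Nothing available here explains why these groups fall as they do.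

The compounds shown leave open whether the fluorine itself matters, since they offer no plain cyclobutyl group for comparison on this carbonyl carbon. They also leave open how a longer carbon chain, or a ring carrying an amine, would read at this position.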